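From fluoro to trifluoromethyl on compound 2

A few compounds are considered here, and "the series" means these few. Any claim that something is new, unique, unknown or untested is made for them only; others in the source may bear on it.

In an ADME assay on MT4 cells (Homo sapiens) for cytotoxicity, read by MTT assay, with a stated time of 5 days (a higher number here means that more compound is tolerated, a lower number that less compound is tolerated), compound 2 (`N#Cc1ccc(Nc2nccc(C(O)c3ccc(-c4ccc(C#N)cc4)cc3F)n2)cc1`) gives 14300 nM. Its nearest neighbour is compound 1 (`N#Cc1ccc(Nc2nccc(C(O)c3ccc(-c4ccc(C#N)cc4)cc3Cl)n2)cc1`), which gives 7540 nM, and the step between them is a 1.9-fold higher number from compound 1 to compound 2 (0.28 log units; within the scatter). The furthest is compound 3 (`N#Cc1ccc(Nc2nccc([C@H](O)c3ccc(-c4ccc(C#N)cc4)cc3F)n2)cc1`), which gives 30000 nM, and that step is a 2.1-fold higher number from compound 2 to compound 3 (0.32 log units; beyond the scatter). What separates those two is the fact that one of compounds 2 and 3 is drawn with a defined configuration and the other without, at the place where they differ.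

Compound 4 (`N#Cc1ccc(Nc2nccc(C(O)c3ccc(-c4ccc(C#N)cc4)cc3C(F)(F)F)n2)cc1`) carries trifluoromethyl in place of fluoro on an aromatic carbon, ortho to a large group and meta to a 4-cyanophenyl group: trifluoromethyl in place of fluoro on an aromatic carbon. The closest evidence is the exchange of chloro and fluoro at that same place, a 1.9-fold higher number from compound 1 to compound 2 (0.28 log units; within the scatter), which stays within the scatter. The step to compound 3 concerns a drawn configuration, not a substituent, so it says little here, as compound 4 is drawn without one, like compound 2. With a single small substituent step as a guide, only a small move is expected, leaning towards the number of compound 1 at 7540 nM and possibly no larger than the scatter. The estimated step is a 1.6-fold lower number from compound 2 to compound 4 (0.20 log units; within the scatter). For compound 4 the expected value is 9000 nM, with an estimated range from 3500 nM to 22000 nM.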

Compound 4, half-maximal cytotoxic concentration: 11400 nM
Compound 4: the middle estimate sits 1.3-fold (0.10 log units) below what was measured; low and high end bracket the measured number.
By their numbers in this assay, from the lowest: compounds 1, 4 and 2 (each within the scatter of the next); then compound 3.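

At this place on the aromatic ring, ortho to a large group, the exchange of fluoro for trifluoromethyl in this assay gives a 1.3-fold lower number from compound 2 to compound 4 (0.10 log units; within the scatter) and the exchange of chloro for trifluoromethyl gives a 1.5-fold higher number from compound 1 to compound 4 (0.18 log units; within the scatter) as its counterpart. With these steps, compounds 1, 2 and 4 all lie within the scatter of one another, so the earlier reading from chloro and fluoro alone now extends to a substituent of 4 heavy atoms, and substituent size as counted in heavy atoms does not separate these three compounds in this assay. No measurement shown here bears on why these three numbers stay together.

The compounds shown leave open whether a group of another kind at this place, such as an amine, a carboxylic acid or a methoxy group, would stay with these three numbers. Also open, on these data alone, is whether compound 4, drawn without a configuration, would show anything like a 2.1-fold higher number from compound 2 to compound 3 (0.32 log units; beyond the scatter) if drawn with one, since that step is known only for the fluoro pair.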